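The source may report more compounds than this note shows. Statements on the series, on what has been measured and on what is new or still open speak of the compounds shown alone.

Compound 2 `COc1cccc(/C=N\NC(=O)C2=C(Cl)c3ccccc3CCC2)c1` stands in a functional assay (MiaPaCa cells, Homo sapiens) for inhibition, read by sulforhodamine B assay, with a stated time of 48 h (on this read-out lower numbers stand for stronger inhibition of growth and higher numbers for weaker inhibition of growth), only at a limit of the assay: compound 2 gives < 10 nM. Compound 1 `Cc1ccc(/C=N\NC(=O)C2=C(Cl)c3ccccc3CCC2)cc1` likewise reaches only a limit, giving < 10 nM. Among the measured compounds shown here, the single measured step, a step that the two limits leave unreadable from compound 1 to compound 2, is therefore unreadable, since both values sit at the limit of < 10 nM in this assay, at which 2 of the 2 values shown sit. Compound 3 `O=C(N/N=C\c1ccc(Cl)cc1)C1=C(Cl)c2ccccc2CCC1` carries 4-chlorophenyl in place of 3-methoxyphenyl on a carbon with a double bond to nitrogen. For the measured compounds named here, no measured step reports on this change; the two limits show only that the shared core keeps strong growth inhibition with either aryl group. Compound 3 is therefore expected to give 5 nM (range 1 nM to 25 nM), an estimated step that the limit leaves unreadable from compound 2 to compound 3, within the scatter.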

Compound 3, concentration for 50% growth inhibition: < 10 nM
Compound 3: only a limit was reported; the forecaster's own chance of this, stated with the estimate: 65%; the middle value is on the limit's open side.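

In this assay compound 3 gives < 10 nM, which is a limit, so no step among compound 1, compound 2 and compound 3 can be read: the limit of < 10 nM in this assay, at which 3 of the 3 values shown sit.

On these data alone, whether these three compounds differ in growth inhibition remains open.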